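Aryl enone acids: cyclohexyl substitution on the aromatic ring

The source may report more compounds than this note shows. Statements on the series, on what has been measured and on what is new or still open speak of the compounds shown alone.

Measured compounds and values in a functional assay on HeLa cells (Homo sapiens) for inhibition, read by MTT assay, with a stated time of 72 h; a higher number here means a weaker inhibitor, a lower number a stronger inhibitor:
compound 1, `O=C(O)/C=C/C(=O)c1ccc(Cl)c(Cl)c1`, 28300 nM
compound 2, `Cc1ccc(C)c(C(=O)/C=C/C(=O)O)c1`, 7860 nM
compound 3, `CC(C)c1ccc(C(C)C)c(C(=O)/C=C/C(=O)O)c1`, 4750 nM

All three compounds share the same acid-bearing enone chain on a substituted benzene ring and differ only in the ring substituents. Compound 2 gives the second highest of the three numbers in this assay. Its nearest neighbour is compound 3, whose number is lower but lies within the scatter of repeated measurements, so no order between compound 2 and compound 3 can be claimed. Compound 1 gives a higher number than compound 2, and that gap lies beyond the scatter.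

Compound 4, `Cc1cc(C2CCCCC2)c(C)cc1C(=O)/C=C/C(=O)O`, is not yet measured. The change from compound 2 to compound 4 is cyclohexyl in place of hydrogen on an aromatic carbon. Both methyl groups of compound 2 remain; only a hydrogen on the aromatic ring is exchanged for the cyclohexyl group.

Among the measured compounds shown here, no measured pair in this set differs in exactly one place, so no step of this kind is available as a guide. Compound 3 carries larger alkyl groups than compound 2, and in this assay compound 3 gives 4750 nM, a number within the scatter of compound 2. On that basis the step expected from compound 2 to compound 4 is a 1.7-fold lower number from compound 2 to compound 4 (0.24 log units; within the scatter), a small move toward a lower number that may not exceed the scatter. Compound 4 is therefore estimated at 4500 nM in this assay, with a range from 1500 nM to 13000 nM.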

Compound 4, half-maximal inhibitory concentration: 2380 nM
Compound 4: the middle estimate sits 1.9-fold (0.28 log units) above what was measured, within the range that was stated.
By their numbers in this assay, from the lowest: compounds 4, 3 and 2 (each within the scatter of the next, the first and the last beyond it); then compound 1.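

In this assay, the series now has its first step between compounds that differ in one place: cyclohexyl in place of hydrogen, on the aromatic carbon para to the (2-carboxyethenyl)carbonyl group, gives a 3.3-fold lower number from compound 2 to compound 4 (0.52 log units; beyond the scatter), a modest step that lies beyond the scatter. This shows that this aromatic carbon, ortho to one methyl group and meta to the other, can carry a cyclohexyl group with both methyl groups kept, and that the exchange moves the number in the lower direction rather than the higher one. No measurement in hand bears on the origin of this step, so the result stands as an observation only.

Still open, on these data alone, is whether the step depends on the cyclohexyl ring itself or would also appear with a cyclopentyl group, a phenyl group, a piperidine ring or a longer alkyl chain at the same carbon. Also open, as far as these compounds go, is whether a cyclohexyl group at this carbon would have a similar effect with two chlorine atoms or two isopropyl groups on the ring in place of the two methyl groups.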